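Replacing a Nitro Group with Methoxy

This account rests on a few compounds, and the source may have more. Where it says the series, first, only, none or still open, it means among the compounds named here.

Among the measured compounds shown here, three related compounds have numbers so far in a functional assay on A549 cells (Homo sapiens) for inhibition, read by MTT assay, with a stated time of 24 h (a lower number here means a stronger inhibitor, a higher number a weaker inhibitor), and compound 2 (`O=[N+]([O-])c1ccc(/C=C/[C@@H]2CCCCN2)cc1`) gives 3.27 ug/mL among them. Compound 3 (`COc1ccccc1/C=C/[C@@H]1CCCCN1`) gives 4.94 ug/mL and lies within the usual scatter of compound 2, so those two cannot be ranked. Compound 1 (`Cc1cccc(C)c1/C=C/[C@@H]1CCCCN1`) gives 7.28 ug/mL and that gap to compound 2 goes beyond the scatter, which makes compound 2 the stronger inhibitor of this pair.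

Compound 4 (`COc1ccc(/C=C/[C@@H]2CCCCN2)cc1`) is still unmeasured. It differs from compound 2 in one place (methoxy in place of nitro on an aromatic carbon), with methoxy in place of nitro on an aromatic carbon.

For the measured compounds named here, no measured pair shows this swap directly, so the evidence is thin. The closest guide is compound 3, which also carries a methoxy group and gives 4.94 ug/mL within the scatter of compound 2. A small rise in the number is therefore expected, and the estimated move is a 1.5-fold higher number from compound 2 to compound 4 (0.17 log units; within the scatter) which would stay within the scatter. In this assay the expected value for compound 4 is 4.8 ug/mL and the estimated range runs from 2.7 ug/mL to 8.5 ug/mL for a single measurement.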

Compound 4, half-maximal inhibitory concentration: 4.33 ug/mL
Beside the measured number, compound 4's estimate is 1.1-fold (0.04 log units) above it; the range from low to high includes it.
By their numbers in this assay, from the lowest: compounds 2, 4, 3 and 1 (each within the scatter of the next, the first and the last beyond it).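

On an aromatic carbon of the six-membered ring, para to a group of 8 heavy atoms, the swap of nitro for methoxy gives a 1.3-fold higher number from compound 2 to compound 4 (0.12 log units; within the scatter) in this assay. Among the compounds shown here, this is the first pair that differs in one place, so the effect of this change can now be read directly rather than inferred from compounds that differ in more than one place, and compound 2 and compound 4 cannot be ranked. At this position, then, going from nitro, with 3 heavy atoms and 2 hydrogen-bond acceptors, to methoxy, with 2 heavy atoms and 1 hydrogen-bond acceptor, produces no difference that repeated measurements could be expected to separate. No measurement of any property of these two groups accompanies this result, so nothing here explains it.

The compounds shown carry only nitro and methoxy at this position, so it stays open whether an amine, a carboxylic acid or a longer chain such as butoxy would leave the number just as unmoved or shift it beyond the scatter. A single pair also leaves open whether the same swap would behave this way on another carbon of the ring or on a different core.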